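A few compounds are considered here, and "the series" means these few. Any claim that something is new, unique, unknown or untested is made for them only; others in the source may bear on it.

Compound 1, `O=S(=O)(/C=C/c1ccc(O)c(O)c1)NCc1ccccc1`: 21500 nM
Compound 2, `O=S(=O)(/C=C/c1ccc(O)c(O)c1)NCCCc1ccccc1`: 17500 nM

Both numbers come from a functional assay on BV-2 cells (Mus musculus) for inhibition, read by Griess assay, with stated times of 3 h and 24 h; a lower number here means a stronger inhibitor, a higher number a weaker inhibitor. Compound 2 gives the lower of the two, but its gap to compound 1 lies within the usual scatter, so the two cannot be told apart. Compound 3, `O=S(=O)(/C=C/c1ccc(O)c(O)c1)NCCCCc1ccccc1`, is not yet measured; it differs from compound 2 by benzyl in place of phenyl on a saturated chain carbon, three bonds along the chain from a sulfonamide nitrogen. Among the measured compounds shown here, no step between two measured compounds is available to size this change, so only a small shift is expected. A step of a 1.2-fold lower number from compound 2 to compound 3 (0.07 log units; within the scatter) is expected, within the scatter. Compound 3 is expected to give about 15000 nM, with a range from 6000 nM to 40000 nM.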

Compound 3, half-maximal inhibitory concentration: 23800 nM
Beside the measured number, compound 3's estimate is 1.6-fold (0.20 log units) below it, within the range that was stated.
By their numbers in this assay, from the lowest: compounds 2, 1 and 3 (each within the scatter of the next).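

Benzyl in place of phenyl on a saturated chain carbon, three bonds along the chain from a sulfonamide nitrogen, gives a 1.4-fold higher number from compound 2 to compound 3 (0.13 log units; within the scatter) in this assay and so leaves compound 2 and compound 3 indistinguishable. Among the compounds shown here, this is the first sized change at this position, and it shows that the position accepts benzyl with no readable effect on the number. Nothing available explains this result.

Still open, going by these compounds, is whether an amine, a carboxylic acid or a longer chain at this position would move the number beyond the scatter. On these data alone, how changes to the shared core would read also remains unknown.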